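A few compounds are considered here, and "the series" means these few. Any claim that something is new, unique, unknown or untested is made for them only; others in the source may bear on it.

Compound 1 `CC1(C)[C@H]2CC[C@]1(C)N(Cc1cn(-c3ccccc3Br)nn1)C(=O)C2`, compound 2 `CC1(C)[C@H]2CC[C@]1(C)N(Cc1cn(-c3ccccc3C#N)nn1)C(=O)C2` and compound 3 `CC1(C)[C@H]2CC[C@]1(C)N(Cc1cn(-c3cccc(O)c3)nn1)C(=O)C2` share one core and differ only in the aromatic group carried on an aromatic nitrogen. In a functional assay on LoVo cells (Homo sapiens) for inhibition, read by MTT assay, with a stated time of 24 h (on this read-out higher numbers stand for weaker inhibition and lower numbers for stronger inhibition), compound 1 gives 60 nM, compound 2 gives 140 nM and compound 3 gives 410 nM. Compound 3 thus has the highest number of the three, which means the weakest inhibition.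

Going by the values given here, compound 4 `Cc1ccccc1-n1cc(CN2C(=O)C[C@@H]3CC[C@@]2(C)C3(C)C)nn1` keeps the core and alters only that group, with 2-methylphenyl in place of 3-hydroxyphenyl on an aromatic nitrogen.

Among the compounds with values here, two measured steps bear on this change, as each compares the 3-hydroxyphenyl group with a phenyl group that has no hydroxy substituent. They are a 6.8-fold higher number from compound 1 to compound 3 (0.83 log units; beyond the scatter) and a 2.9-fold higher number from compound 2 to compound 3 (0.47 log units; beyond the scatter), both modest but beyond the scatter. The phenyl groups bearing bromo and cyano do not match each other either, with a 2.3-fold higher number from compound 1 to compound 2 (0.37 log units; beyond the scatter), so the size of the next step remains uncertain. Within the data shown here, no methyl-bearing compound has been measured, and three compounds make a guide rather than a rule.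

A modest move towards stronger inhibition seems likely, and the expected step is a 3.7-fold lower number from compound 3 to compound 4 (0.57 log units; beyond the scatter). In this assay, the estimate for compound 4 is 110 nM, with an expected range from 40 nM to 300 nM.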

Compound 4, half-maximal inhibitory concentration: 80 nM
Beside the measured number, compound 4's estimate is 1.4-fold (0.14 log units) above it; the range from low to high includes it.
By their numbers in this assay, from the lowest: compounds 1, 4 and 2 (each within the scatter of the next, the first and the last beyond it); then compound 3.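

In this assay the change to 2-methylphenyl gives a 5.1-fold lower number from compound 3 to compound 4 (0.71 log units; beyond the scatter) and extends the pattern: 2-methylphenyl, like the 2-bromophenyl of compound 1 and the 2-cyanophenyl of compound 2, gives a lower number than the 3-hydroxyphenyl of compound 3, and none of the four compounds goes against this. Methyl in place of cyano gives a 1.8-fold lower number from compound 2 to compound 4 (0.24 log units; within the scatter) and methyl in place of bromo gives a 1.3-fold higher number from compound 1 to compound 4 (0.12 log units; within the scatter), both within the scatter, so a group built only of carbon and hydrogen cannot be ranked against either of those two. Nothing shown here gives a measured reason for these differences.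

The step from compound 3 to compound 4 changes both the substituent and where it sits on the phenyl ring, so the compounds shown cannot say which of the two matters; a 3-methylphenyl or a 2-hydroxyphenyl group would separate them. As far as these compounds go, it also remains open how a plain phenyl group, with no substituent at all, or a 2-methoxyphenyl or 2-aminophenyl group would compare.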